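Shifting the trifluoromethoxy group in compound 2

A few compounds are considered here, and "the series" means these few. Any claim that something is new, unique, unknown or untested is made for them only; others in the source may bear on it.

- compound 1 `CC(O)(CS(=O)(=O)c1ccc(F)cc1)C(=O)Nc1ccc(S(F)(F)(F)(F)F)cc1`: 18200 nM
- compound 2 `CC(O)(CS(=O)(=O)c1ccc(OC(F)(F)F)cc1)C(=O)Nc1ccc(S(F)(F)(F)(F)F)cc1`: 92800 nM

Going by the values given here, in a functional assay on LNCaP cells (Homo sapiens) for antiproliferative activity, read by propidium iodide staining, with a stated time of 96 h (on this read-out lower numbers stand for stronger inhibition and higher numbers for weaker inhibition), compound 2 gives 92800 nM, the higher of the two numbers so far, which makes it the weaker inhibitor of the pair. Among the compounds with values here, the only comparison available is a 5.1-fold higher number from compound 1 to compound 2 (0.71 log units; beyond the scatter), a modest step that lies beyond the scatter and goes with trifluoromethoxy in place of fluoro on an aromatic carbon.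

Compound 3 `CC(O)(CS(=O)(=O)c1cccc(OC(F)(F)F)c1)C(=O)Nc1ccc(S(F)(F)(F)(F)F)cc1` has the same atoms as compound 2, joined differently: 3-(trifluoromethoxy)phenyl in place of 4-(trifluoromethoxy)phenyl on a sulfonyl sulfur. In words, it carries 3-(trifluoromethoxy)phenyl in place of 4-(trifluoromethoxy)phenyl on a sulfonyl sulfur.

The measured step bears on this change only loosely, since it swapped one group for another, whereas here the group stays the same. Within the data shown here, no measured pair shows what this kind of change does, so the direction remains uncertain. A step no larger than a 5.1-fold higher number from compound 1 to compound 2 (0.71 log units; beyond the scatter) is expected in this assay, leaning slightly toward a lower number, as compound 2 holds the higher of the two values.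

The expected change is a 1.7-fold lower number from compound 2 to compound 3 (0.23 log units; within the scatter).

For compound 3 the estimated value is 55000 nM, with an expected range from 18000 nM to 130000 nM.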

Compound 3, half-maximal inhibitory concentration: 21700 nM
Estimate against measurement, compound 3: 2.5-fold (0.40 log units) above; the range from low to high includes it.
By their numbers in this assay, from the lowest: compounds 1 and 3 (each within the scatter of the next); then compound 2.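

In this assay, moving the trifluoromethoxy group while keeping every atom gives a 4.3-fold lower number from compound 2 to compound 3 (0.63 log units; beyond the scatter), a modest step that lies beyond the scatter. The aryl group on the sulfonyl sulfur therefore responds not only to which group it carries, as the swap of fluoro for trifluoromethoxy showed, but also to where that group sits, so 3-(trifluoromethoxy)phenyl and 4-(trifluoromethoxy)phenyl are not interchangeable in this series. The other new comparison is a 1.2-fold higher number from compound 1 to compound 3 (0.08 log units; within the scatter), which lies within the scatter, so the trifluoromethoxy group does not by itself go with a higher number than fluoro; that holds only for the 4-(trifluoromethoxy)phenyl form in compound 2. Nothing available explains why the placement matters.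

As far as these compounds go, whether fluoro responds to the same shift, from 4-fluorophenyl to 3-fluorophenyl, remains open, and a single pair cannot show whether the placement effect is general. From the compounds shown here alone, how an amine or a nitrile on the same aromatic ring would behave in either placement also remains open.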